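The source may hold more compounds than are shown below. What is called first, only, known or untested is meant among the compounds shown, and "the series" means these compounds.

Going by the values given here, in a functional assay on HEK293 cells (Homo sapiens) for cytotoxicity (a higher number here means that more compound is tolerated, a lower number that less compound is tolerated), none of the three compounds measured so far has given a number. Compound 1 (`COc1ccc([C@H]2CC(=O)N(c3cccc(O)c3)C2)cc1OC1CCCC1`) reaches only the limit > 10000 nM. Compound 2 (`COc1ccc([C@H]2CC(=O)N(c3cccc(C)c3)C2)cc1OC1CCCC1`) also reaches only the limit > 10000 nM. Compound 3 (`COc1ccc([C@H]2CC(=O)N(c3cccc(NS(=O)(=O)c4cc(C)ccc4OC)c3)C2)cc1OC1CCCC1`) likewise stands at a limit, > 10000 nM, so its position is bounded on one side only.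

Compound 4 (`COc1ccc([C@H]2CC(=O)N(c3cccc(NS(=O)(=O)c4ccccc4F)c3)C2)cc1OC1CCCC1`) differs from compound 3 on a sulfonyl sulfur, where 2-fluorophenyl stands in place of 2-methoxy-5-methylphenyl: 2-fluorophenyl in place of 2-methoxy-5-methylphenyl on a sulfonyl sulfur. Among the compounds with values here, the only measured step is a step that the two limits leave unreadable from compound 1 to compound 2, which swaps methyl for hydroxy on an aromatic carbon, elsewhere in the structure. It therefore offers no size to carry over. What remains is the limit of > 10000 nM in this assay, at which 3 of the 3 values shown sit.

In this assay, no step beyond the scatter is therefore expected, and the direction cannot be told. The expected step is a step that the limit leaves unreadable from compound 3 to compound 4. For compound 4 the estimated value is 15000 nM, expected to fall between 7000 nM and 40000 nM, and it will most likely be reported only as a limit.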

Compound 4, half-maximal cytotoxic concentration: > 10000 nM
Compound 4: no number, only a limit (the forecaster's own chance of this, stated with the estimate: 85%); the middle value does not contradict the limit.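

In this assay compound 4 gives only a limit, > 10000 nM. Its steps from compound 1, compound 2 and compound 3 cannot be read. The compounds shown leave open at what concentration any of them becomes cytotoxic, because none gives a number: the limit of > 10000 nM in this assay, at which 4 of the 4 values shown sit.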